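The compounds below may be only part of what the source reports. "The series", "measured", "known", "first", "only" and "open" are said of these compounds alone.

Measured so far:
Compound 1, `O=C1c2c[n+]([O-])c3ccccc3c2C(=O)c2c1c1ccccc1n2CCCCn1ccnc1`: in a functional assay on SH-SY5Y cells (Homo sapiens) for cytotoxicity, read by MTT assay, with a stated time of 72 h (a higher number here means a weaker inhibitor, a lower number a stronger inhibitor), compound 1 gives 130 nM.
Compound 2, `O=C1c2c[n+]([O-])c3ccccc3c2C(=O)c2c1c1ccccc1n2Cc1cn([C@H]2C[C@H](O)[C@@H](CO)O2)nn1`: in this assay compound 2 gives 620 nM.

Of the two numbers in hand, compound 1 has the lower one, and a lower number here means the stronger inhibitor of cell growth. For the measured compounds named here, its only neighbour, compound 2, carries a higher number, and the gap between the two lies beyond the usual scatter of this kind of measurement. The two compounds share the same core and differ only in the group attached to the ring nitrogen, so nothing more can be drawn from them than this single comparison.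

Compound 3, `O=C1c2c[n+]([O-])c3ccccc3c2C(=O)c2c1c1ccccc1n2CCN1CCCCC1`, keeps the core of compound 1 and changes the side chain: piperidin-1-yl in place of 2-(1H-imidazol-1-yl)ethyl on a saturated chain carbon, two bonds along the chain from an aromatic nitrogen. Going by the values given here, no measured pair in this set shows what such a swap does. Both chains end in a ring with a basic nitrogen and are of comparable size, with no change in charge. The step from compound 1 to compound 3 is therefore expected to stay within the scatter, a 1.2-fold higher number from compound 1 to compound 3 (0.06 log units; within the scatter). For compound 3 the estimated value in this assay is 150 nM, expected to fall between 60 nM and 400 nM.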

Compound 3, half-maximal inhibitory concentration: 1860 nM
For compound 3 the middle estimate is 12-fold (1.09 log units) below the measured one; the measured number lies above the stated range.
By their numbers in this assay, from the lowest: compound 1; then compound 2; then compound 3.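

In this assay the swap of piperidin-1-yl for 2-(1H-imidazol-1-yl)ethyl on a saturated chain carbon, two bonds along the chain from an aromatic nitrogen, gives a 14-fold higher number from compound 1 to compound 3 (1.16 log units; beyond the scatter) and so shows that this position does not tolerate every ring-ended chain of similar size. Cut one bond further out, the same difference reads 4-(1H-imidazol-1-yl)butyl to 2-(piperidin-1-yl)ethyl, which means that the group at the end of the chain and the length of the chain change together, and this one step cannot tell their contributions apart. Nothing measured here explains why the number rises.

The compounds shown leave open which of the two changes matters: a 4-(piperidin-1-yl)butyl chain or a 2-(1H-imidazol-1-yl)ethyl chain on the same core would each alter only one of them. They also leave open how an open-chain amine such as diethylamino, or a morpholine ring, would compare with piperidin-1-yl at the end of the shorter chain.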